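Phenyl for isopropyl: from compound 1 to compound 3

The source may report more compounds than this note shows. Statements on the series, on what has been measured and on what is new or still open speak of the compounds shown alone.

Measured so far, in a functional assay on SW480 cells (Homo sapiens) for cytotoxicity, read by MTT assay, with a stated time of 24 h; a higher number here means a weaker inhibitor, a lower number a stronger inhibitor:
- compound 1 `C=CC1=C(C(=O)NCC(C)C)C(c2ccc(Cl)c(Cl)c2)OC1` — compound 1 gives > 100000 nM, which is a limit of the assay, not a number
- compound 2 `C=CC1=C(C(=O)Nc2cccc(C)c2)C(c2ccc(F)cc2)OC1` — compound 2 gives > 100000 nM, likewise a limit

For the measured compounds named here, compound 1 therefore has no measured potency at all; it sits at the limit, and that is also where compound 2 sits, so that the limit of > 100000 nM in this assay, at which 2 of the 2 values shown sit, is the only evidence available and no step between measured compounds exists.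

Compound 3 `C=CC1=C(C(=O)NCc2ccccc2)C(c2ccc(Cl)c(Cl)c2)OC1` differs from compound 1 in one place: phenyl in place of isopropyl on a saturated chain carbon bound to an amide-type nitrogen. With both known values at the limit, nothing indicates that this swap would bring the value into the measurable range, so the step in this assay is expected to be none beyond the usual scatter and most likely to end at the limit again.

For compound 3 the estimate is 150000 nM, within 40000 nM to 500000 nM, which means an expected step that the limit leaves unreadable from compound 1 to compound 3.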

Compound 3, half-maximal inhibitory concentration: > 100000 nM
Compound 3: a limit, no number; the forecaster's own chance of this, stated with the estimate: 80%; the middle value does not contradict the limit.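

In this assay compound 3 gives > 100000 nM, which is a limit and not a number, and compound 1 also sits at a limit, so no step can be read between them. The compounds shown leave open which structures, if any, would give a measurable value: the limit of > 100000 nM in this assay, at which 3 of the 3 values shown sit.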